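Swapping methyl for nitro on a weak growth inhibitor

The source may report more compounds than this note shows. Statements on the series, on what has been measured and on what is new or still open speak of the compounds shown alone.

For the measured compounds named here, in a functional assay on HCT-15 cells (Homo sapiens) for inhibition, read by sulforhodamine B assay (a higher number here means a weaker inhibitor of growth, a lower number a stronger inhibitor of growth), compound 1 (`Cc1ccc(CN2CCC=C(CCC(=O)NO)C2=O)cc1`) gives 8510 nM, the only actual number so far. Compound 2 (`Cc1cccc(CN2CCC=C(CCC(=O)NO)C2=O)c1`) gives > 10000 nM, which is a limit of the assay and not a number. Compound 3 (`O=C(CCC1=CCCN(Cc2ccc([N+](=O)[O-])cc2)C1=O)NO`) keeps the core of compound 1 and changes one group: nitro in place of methyl on an aromatic carbon. In short, nitro replaces methyl on an aromatic carbon, para to a large group. Going by the values given here, only one measured step offers any guide, an at least 1.1-fold higher number from compound 1 to compound 2 (0.07 log units; that floor lies within the scatter), which places 3-methylphenyl where 4-methylphenyl stood. That step moves a methyl and does not replace it, so it bears on this change only loosely. Going by these compounds, no step beyond the scatter is therefore expected in this assay, and the direction stays open. The expected change is a 1.2-fold lower number from compound 1 to compound 3 (0.08 log units; within the scatter). For compound 3 the estimated value is 7000 nM, with an expected range of 3000 nM to 10000 nM.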

Compound 3, concentration for 50% growth inhibition: > 10000 nM
Compound 3 ended at the assay's limit; the forecaster's own chance of this, stated with the estimate: 30%; middle value at least 1.4-fold (0.15 log units) away from the limit.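

In this assay, nitro in place of methyl on the aromatic carbon gives an at least 1.1-fold higher number from compound 1 to compound 3 (0.07 log units; that floor lies within the scatter). Compound 3 gives > 10000 nM, which is a limit of the assay and not a number, so the true size of this step cannot be read, and nitro shows no sign of a stronger growth inhibitor at this position. The earlier compounds shown here only moved the methyl, whereas this result replaces it, and the series now piles up at a single ceiling: the limit of > 10000 nM in this assay, at which 2 of the 3 values shown sit.

The compounds shown leave open what an amine, a carboxylic acid or a longer chain on that aromatic carbon would give in this assay. For the compounds shown here, they also leave open whether any such group would improve clearly on compound 1, which gives 8510 nM, the only actual number so far.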